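This account rests on a few compounds, and the source may have more. Where it says the series, first, only, none or still open, it means among the compounds named here.

Of the compounds shown here, three have been measured in an assay on CHO cells for displacement of a labelled ligand from transmembrane domain-containing protein TMIGD3 (Homo sapiens); on this read-out higher numbers stand for weaker inhibition and lower numbers for stronger inhibition. Compound 1 `O=c1oc2c(O)c(O)ccc2cc1-c1cccs1` gives 4830 nM, and compound 2 `O=c1oc2c(O)c(O)ccc2cc1-c1ccsc1` gives 5310 nM; the step of a 1.1-fold higher number from compound 1 to compound 2 (0.04 log units; within the scatter) shows that swapping the attachment point of the outer ring leaves the number essentially unchanged. Compound 3 `O=c1oc2c(O)cccc2cc1-c1cc(Br)cs1` gives 746 nM, the lowest of the three numbers, and its distance from compound 1 and from compound 2 lies beyond the scatter. Compound 3 differs from compound 1 in two places at once, so its two values alone cannot say which of those two changes matters.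

Compound 4 `O=c1oc2c(O)c(O)ccc2cc1-c1cc(Br)cs1` is the next step from compound 3: hydroxy in place of hydrogen on an aromatic carbon. For the measured compounds named here, no measured step isolates this change; the only measured step, from compound 1 to compound 2, concerns the outer ring and says nothing about adding a hydroxy group to the shared core. The comparison of compound 1 with compound 3 is confounded by the bromine. The expectation for compound 4 is therefore uncertain, with only a mild shift toward a higher number expected, a 1.9-fold higher number from compound 3 to compound 4 (0.27 log units; within the scatter). Compound 4 is thus estimated at 1400 nM, within a range from 350 nM to 5500 nM.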

Compound 4, inhibition constant: 3400 nM
Compound 4: the middle estimate sits 2.4-fold (0.39 log units) below what was measured; the range from low to high includes it.
By their numbers in this assay, from the lowest: compound 3; then compounds 4, 1 and 2 (each within the scatter of the next).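

On the core of compound 3, the added hydroxy, ortho to a hydroxy group, gives a 4.6-fold higher number from compound 3 to compound 4 (0.66 log units; beyond the scatter) in this assay and so is a real loss of binding strength on this read-out. Bromo in place of hydrogen on the outer ring gives a 1.4-fold lower number from compound 1 to compound 4 (0.15 log units; within the scatter) and the swap of the whole outer ring gives a 1.6-fold lower number from compound 2 to compound 4 (0.19 log units; within the scatter) on the core that carries this hydroxy, and both steps stay within the usual scatter. Of the two changes that separate compound 1 from compound 3, only the hydroxy step therefore stands clear of the scatter when read on its own, while bromo shows no measurable effect once that hydroxy is present.

Still open, from the compounds shown here alone, is whether bromo would matter on the core without this hydroxy, and whether a methoxy group, an amine or a fluorine at the same position would behave like hydrogen or like hydroxy. Nothing available here offers an explanation for the size of the hydroxy step.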